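Adding an Isopropylcarbamoyl Group to a Weak Desaturase Inhibitor

A few compounds are considered here, and "the series" means these few. Any claim that something is new, unique, unknown or untested is made for them only; others in the source may bear on it.

Of the compounds shown here, three built on one shared core have been tested so far. Compound 1 `CNC(=O)c1cccc(NC(=O)N2CCC(Oc3ccccc3OC)CC2)c1` gives 81 nM in an assay on isolated protein for inhibition of acyl-CoA desaturase 1 (Mus musculus); a higher number here means a weaker inhibitor, a lower number a stronger inhibitor. Compound 2 `CNC(=O)c1cccc(NC(=O)N2CCC(Oc3c(F)cccc3Cl)CC2)c1` gives 330 nM in this assay. Compound 3 `O=C(Nc1ccccc1)N1CCC(Oc2ccccc2Cl)CC1` gives 590 nM in this assay, the highest of the three numbers; against compound 2 the gap is within the scatter, against compound 1 it is not.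

For the measured compounds named here, the one measured step is a 4.1-fold higher number from compound 1 to compound 2 (0.61 log units; beyond the scatter), a modest loss on changing the group on the oxygen on a saturated carbon. Compound 4 `CC(C)NC(=O)c1cccc(NC(=O)N2CCC(Oc3ccccc3Cl)CC2)c1` differs from compound 3 in a different way: isopropylcarbamoyl in place of hydrogen on an aromatic carbon. Going by the values given here, no measured pair shows this change on its own. Compounds 1 and 2 carry a smaller relative of this group on their aromatic ring, yet they also differ from compound 3 in the group on the oxygen on a saturated carbon, so their numbers cannot be read as the effect of the new group alone.

With that limited guidance, a small gain is expected for compound 4, a step of a 2.0-fold lower number from compound 3 to compound 4 (0.29 log units; within the scatter), giving an estimate of 300 nM with a range from 100 nM to 900 nM.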

Compound 4, half-maximal inhibitory concentration: 810 nM
Compound 4: the middle estimate sits 2.7-fold (0.43 log units) below what was measured; the measured number falls inside the stated range.
By their numbers in this assay, from the lowest: compound 1; then compounds 2, 3 and 4 (each within the scatter of the next, the first and the last beyond it).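

For the compounds shown here, compound 3 and compound 4 form the first measured pair that isolates this change: isopropylcarbamoyl in place of hydrogen on an aromatic carbon, meta to a large group, gives a 1.4-fold higher number from compound 3 to compound 4 (0.14 log units; within the scatter) in this assay. The two compounds therefore cannot be told apart in this assay, so this single pair shows that a group of this size can occupy the position without a shift beyond the scatter, in either direction. Nothing available explains this outcome.

Going by these compounds, the pair speaks only for the group on the oxygen that compound 3 and compound 4 share, so it remains open whether isopropylcarbamoyl would have a similarly small effect alongside the 2-methoxyphenyl group of compound 1, or how the smaller methylcarbamoyl group of compound 1 would read alongside the group on the oxygen of compound 3. Also open, on these data alone, is whether a very different group on the same aromatic carbon, such as a carboxylic acid, an amine or a longer chain, would move the number beyond the scatter.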